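The source may report more compounds than this note shows. Statements on the series, on what has been measured and on what is new or still open speak of the compounds shown alone.

Working notes on a four-compound series.

Within the data shown here, compound 1 `COc1ccc(CCCc2ccc(OC)cc2OC)c(O)c1` is the first anchor; in an ADME assay on RAW264.7 cells (Mus musculus) for cytotoxicity, read by MTT assay, with a stated time of 24 h, tested at 10 ug/mL (a lower number here means a stronger effect, a higher number a weaker effect of the compound at the concentration tested), compound 1 gives 25.8%. Compound 2 `COc1ccc(CCCc2ccc(OC)c(OC)c2OC)c(O)c1` differs from it by methoxy in place of hydrogen on an aromatic carbon, and in this assay compound 2 gives 36.7%. The step of a number 10.9 percentage points higher from compound 1 to compound 2 (beyond the scatter) is modest but outside the scatter, and points toward a weaker effect.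

Compound 3 `COc1ccc(C(=O)CCc2ccc(OC)c(OC)c2)c(O)c1` carries a different core; the difference between the core of compound 1 and the core of compound 3 is not broken down here. In this assay compound 3 gives 67.5%, the highest number of the three measured compounds, with both compound 1 and compound 2 lying well below it.

Compound 4 `COc1ccc(C(=O)CCc2ccc(OC)c(OC)c2OC)c(O)c1` is not yet measured. It differs from compound 3 by methoxy in place of hydrogen on an aromatic carbon. This is the same kind of change as from compound 1 to compound 2, not the same: in compound 2 the entering methoxy sits ortho to two methoxy groups and meta to a large group, whereas in compound 4 it sits ortho to a large group, ortho to a methoxy group and meta to a methoxy group. Among the measured compounds shown here, the only measured precedent is a number 10.9 percentage points higher from compound 1 to compound 2 (beyond the scatter), so for compound 4 a step of similar size and direction is expected, a number 8.5 percentage points higher from compound 3 to compound 4 (within the scatter), bounded by the fact that compound 3 already sits high with 67.5%. Compound 4 is therefore estimated at 76%, within 58% to 92%.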

Compound 4, a percentage reported as activity, at one concentration (the size of the read-out at that concentration, not a potency): 94%
Compound 4: middle estimate off by 18 percentage points, on the low side; the measured number lies above the stated range.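

In this assay, methoxy in place of hydrogen on an aromatic carbon gives a number 26.5 percentage points higher from compound 3 to compound 4 (beyond the scatter), and set beside the earlier step on the other core, this step does not match it in size: the same change on two cores in this assay, a number 10.9 percentage points higher (beyond the scatter) from compound 1 to compound 2 and a number 26.5 percentage points higher (beyond the scatter) from compound 3 to compound 4, 15.6 percentage points apart, beyond the scatter of two such steps. Both steps point toward a weaker effect, so across these two pairs the direction of the change carries from one core to the other, while its size does not. The two pairs do not show why the sizes differ, as the cores and the surroundings of the entering methoxy both change from one pair to the other, and they do not show how the change would behave on a third core.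

Open, as far as these compounds go, is whether the larger step belongs to the carbonyl in the core of compound 3 or to the place of the entering methoxy. Also open, from the compounds shown here alone, is whether an amine or a carboxylic acid entering at that place would shift the read-out in the same direction as methoxy.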